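Ethoxycarbonyl in place of methyl on compound 1

The source may report more compounds than this note shows. Statements on the series, on what has been measured and on what is new or still open speak of the compounds shown alone.

Among the compounds with values here, in an ADME assay on Vero cells (Chlorocebus sabaeus) for cytotoxicity, read by crystal violet staining (on this read-out lower numbers stand for higher toxicity in this test and higher numbers for lower toxicity in this test), compound 1 `CN1CCN(/N=N/c2ccccc2)CC1` gives 45000 nM, the only actual number so far. Compound 2 `CN(Cc1ccccc1)/N=N/c1ccccc1` is reported only as a limit, >= 100000 nM. Compound 3 `CCOC(=O)N1CCN(/N=N/c2ccccc2)CC1` carries ethoxycarbonyl in place of methyl on an amine nitrogen in a ring of the core of compound 1 (ethoxycarbonyl in place of methyl on an amine nitrogen in a ring). Within the data shown here, no measured step bears on this change, so only a modest move towards higher numbers in this assay is expected, barely beyond the scatter. The expected size of this move is a 1.3-fold higher number from compound 1 to compound 3 (0.12 log units; within the scatter). For compound 3 the estimated value is 60000 nM, with an expected range of 25000 nM to 100000 nM.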

Compound 3, half-maximal cytotoxic concentration: 90000 nM
Compound 3: middle estimate off by 1.5-fold (0.18 log units), on the low side; measured number inside the range.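

Within the data shown here, at this ring nitrogen, the only measured step in this assay shows that ethoxycarbonyl in place of methyl on an amine nitrogen in a ring gives a 2.0-fold higher number from compound 1 to compound 3 (0.30 log units; within the scatter). Exchanging methyl for this larger group, which brings a carbonyl and hydrogen-bond acceptors, therefore produces no change beyond the scatter. Any higher number at this position would soon meet the top of the reported range: the limit of >= 100000 nM in this assay, at which 1 of the 3 values shown sits.

From the compounds shown here alone, whether an acetyl group, a carboxylic acid or a longer alkyl chain on this nitrogen would move the number beyond the scatter remains open. A single step cannot establish a trend at this position.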